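This account rests on a few compounds, and the source may have more. Where it says the series, first, only, none or still open, it means among the compounds named here.

The measured compounds and their values in a functional assay on Jurkat cells (Homo sapiens) for activation, with a stated time of 24 h; on this read-out higher numbers stand for an effect only at larger amounts of compound and lower numbers for an effect already at smaller amounts:

- compound 1 `Oc1ccccc1CNc1ccccc1`: "not active" (no number reported)
- compound 2 `COc1ccc(-c2ccc(NCc3ccccc3O)cc2)cc1`: 580 nM
- compound 3 `COc1cccc(-c2ccc(NCc3ccccc3O)cc2)c1`: "not active" (no number reported)

Compound 1 stands without a single number in this assay: it is reported as not active, and compound 3 is a further entry without a number. Only compound 2 gives a value, and in this assay compound 2 gives 580 nM. Compound 2 and compound 3 differ from each other only in where a methoxy group sits on their added ring, and one is active while the other is not, so small changes on that ring matter here.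

Compound 4 `Cc1ccccc1-c1ccc(NCc2ccccc2O)cc1` comes from compound 1 by a single change: 2-methylphenyl in place of hydrogen on an aromatic carbon. For the measured compounds named here, no step between measured compounds covers this pair. Since compound 1 has no number, the step can only be judged against compound 2 and compound 3, which share the same pattern of an added ring on the core and split between an active value and none at all. The expected direction is toward activity, as compound 2 shows with 580 nM, but with a real chance that, like compound 3, nothing measurable appears. For compound 4 the estimated value is 2000 nM, expected within 400 nM to 10000 nM.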

Compound 4, half-maximal effective concentration: 5220 nM
For compound 4 the middle estimate is 2.6-fold (0.42 log units) below the measured one; the range from low to high includes it.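

In this assay compound 4 gives 5220 nM, while compound 1 is reported as not active with no number, so no step can be read between them. The compounds shown leave open how large an effect the 2-methylphenyl group itself has on the shared core. No available evidence accounts for the value of compound 4.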